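The compounds below may be only part of what the source reports. "The series", "measured", "known", "first", "only" and "open" are said of these compounds alone.

Measured so far, in a functional assay on MCF7 cells (Homo sapiens) for cytotoxicity, read by MTT assay, with a stated time of 72 h; a lower number here means a stronger inhibitor, a higher number a weaker inhibitor:

Compound 1, `COc1ccc(/C=C/C(=O)Nc2cc3c(Nc4ccc(F)c(Cl)c4)ncnc3cc2O[C@H]2CCOC2)c(OC)c1`, gives 28600 nM.
Compound 2, `COc1ccc(/C=C/C(=O)Nc2cc3c(Nc4ccc(F)c(Cl)c4)ncnc3cc2O[C@H]2CCOC2)c(OC)c1OC`, gives 4650 nM.
Compound 3, `COc1cc(/C=C/C(=O)Nc2cc3c(Nc4ccc(F)c(Cl)c4)ncnc3cc2OC)cc(OC)c1`, gives 38500 nM.

Compound 3 stands highest of the three numbers; against compound 1 the gap is within the scatter, against compound 2 it is beyond it. The difference between the core of compound 1 and the core of compound 3 is not broken down here.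

Compound 4, `COc1cc2ncnc(Nc3ccc(F)c(Cl)c3)c2cc1NC(=O)/C=C/c1cc(OC)c(OC)c(OC)c1`, is not yet measured in this assay. It differs from compound 3 by methoxy in place of hydrogen on an aromatic carbon. The same kind of change has been made once before in this set: compound 2 differs from compound 1 by methoxy in place of hydrogen on an aromatic carbon. The two places are not identical: in the earlier pair the entering methoxy is meta to a large group, in the new pair it is para to a large group. The earlier step, a 6.2-fold lower number from compound 1 to compound 2 (0.79 log units; beyond the scatter), is modest but beyond the scatter.

Going by the values given here, for compound 4 a step in the same direction is expected, a 3.9-fold lower number from compound 3 to compound 4 (0.59 log units; beyond the scatter), resting on the single precedent a 6.2-fold lower number from compound 1 to compound 2 (0.79 log units; beyond the scatter) and tempered because the surroundings of the place differ and compound 3 starts from a high value, 38500 nM. Compound 4 is accordingly estimated at 10000 nM in this assay, with a likely range from 3500 nM to 30000 nM.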

Compound 4, half-maximal inhibitory concentration: "not active" (no number reported)
Nothing numeric was reported for compound 4, and the estimate cannot be compared.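

In this assay, going by these compounds alone, compound 4 is reported only as "not active", with no number, so no step from compound 3 to compound 4 can be read. The compounds shown leave open whether the earlier methoxy step (a 6.2-fold lower number from compound 1 to compound 2 (0.79 log units; beyond the scatter)) has a counterpart in the change from 3,5-dimethoxyphenyl to 3,4,5-trimethoxyphenyl. No data shown bear on the reason for this result.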